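Cytotoxicity limits across the series; next step to chloro

A few compounds are considered here, and "the series" means these few. Any claim that something is new, unique, unknown or untested is made for them only; others in the source may bear on it.

Measured so far in an ADME assay on Raji cells (Homo sapiens) for cytotoxicity, read by CellTiter-Glo and resazurin assay, with a stated time of 72 h (a higher number here means that more compound is needed for the effect, a lower number that less compound is needed), each value a limit of the assay rather than a number:
compound 1 `CCOC(=O)CCCCCOc1cccc(CN(C(=O)c2ccc(-c3cccc(OCC)c3)cc2)C(C)C)c1`: > 22300 nM
compound 2 `CCOC(=O)CCCCCOc1cccc(CN(C(=O)c2ccc(-c3cccc(O)c3)cc2)C(C)C)c1`: > 26000 nM
compound 3 `CCOC(=O)CCCCCOc1cccc(CN(C(=O)c2ccc(-c3cccc(C(F)(F)F)c3)cc2)C(C)C)c1`: > 26000 nM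

Compound 3 stands at a limit, and so do the two others. The steps a step that the two limits leave unreadable from compound 1 to compound 3 and a step that the two limits leave unreadable from compound 2 to compound 3 have no readable size, nor does a step that the two limits leave unreadable from compound 1 to compound 2. Among the compounds with values here, the only evidence is the limit of > 22300 nM in this assay, at which 1 of the 3 values shown sits, and (the limit of > 26000 nM in this assay, at which 2 of the 3 values shown sit).

Compound 4 `CCOC(=O)CCCCCOc1cccc(CN(C(=O)c2ccc(-c3cccc(Cl)c3)cc2)C(C)C)c1` differs from compound 3 by chloro in place of trifluoromethyl on an aromatic carbon. Within the data shown here, no measured step speaks to this change with a readable size; all three compounds sit at limits, so no step beyond the scatter is expected. Compound 4 is expected to sit at or near a limit as well, estimated at 26000 nM, ranging from 9000 nM to 60000 nM, which corresponds to an expected a number no higher from compound 3 to compound 4 (the limit leaves the size open).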

Compound 4, half-maximal effective concentration: > 18400 nM
Compound 4: a limit, no number (the forecaster's own chance of this, stated with the estimate: 80%); the middle value lies beyond the limit too.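

Within the data shown here, compound 4 stands at a limit, as do compound 1, compound 2 and compound 3, so no step among them can be read in this assay. The compounds shown leave open whether chloro, trifluoromethyl, hydroxy and ethoxy differ at all here.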